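Adding a (tert-butyl)carbonyl ester to compound 3

This account rests on a few compounds, and the source may have more. Where it says the series, first, only, none or still open, it means among the compounds named here.

In a functional assay on NCI/ADR-RES cells (Homo sapiens) for positive allosteric modulation, read by MTT assay, with a stated time of 48 h, tested at 10 uM (on this read-out lower numbers stand for stronger inhibition and higher numbers for weaker inhibition), compound 1 `C=C1[C@H](OCC(C)C)[C@@H](OC(C)=O)[C@@H](OC(C)=O)C(C)(C)/C=C/[C@H](C)[C@H](OC(=O)c2ccccc2)[C@@]2(O)C[C@@](C)(OC(C)=O)[C@H](OC(C)=O)[C@@H]2[C@H]1OCC(C)C` gives 4860 nM and compound 2 `C=C1[C@H](OCC(C)C)C2=C(C[C@@](C)(OC(C)=O)[C@@H]2OC(C)=O)[C@@H](OC(=O)c2ccccc2)[C@@H](C)/C=C/C(C)(C)[C@H](OC(C)=O)[C@H](OC(C)=O)[C@H]1OCC(C)C` gives 3700 nM, two values within the scatter of each other. Compound 3 `C=C1[C@H](O)[C@@H](O)[C@@H](O)C(C)(C)/C=C/[C@H](C)[C@H](OC(=O)c2ccccc2)[C@@]2(O)C[C@@](C)(O)[C@H](OC(C)=O)[C@@H]2[C@H]1OCC(C)C` gives > 100000 nM, which is a limit of the assay and not a number. Compound 4 `C=C1[C@H](O)[C@@H](OC(=O)C(C)(C)C)[C@@H](O)C(C)(C)/C=C/[C@H](C)[C@H](OC(=O)c2ccccc2)[C@@]2(O)C[C@@](C)(O)[C@H](OC(C)=O)[C@@H]2[C@H]1OCC(C)C` differs from compound 3 by (tert-butyl)carbonyl in place of hydrogen on an oxygen on a saturated carbon, turning a hydroxy into ((tert-butyl)carbonyl)oxy. Compound 1 at 4860 nM and compound 2 at 3700 nM carry ester groups where compound 3 has free hydroxy groups, so a move toward stronger inhibition in this assay is expected. The estimated step is an at least 4.0-fold lower number from compound 3 to compound 4 (0.60 log units; beyond the scatter), and its size is uncertain. For compound 4 the expected value is 25000 nM, with an estimated range of 6000 nM to 100000 nM.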

Compound 4, half-maximal inhibitory concentration: 64200 nM
Compound 4: middle estimate off by 2.6-fold (0.41 log units), on the low side, within the range that was stated.
By their numbers in this assay, from the lowest: compounds 2 and 1 (each within the scatter of the next); then compound 4. At a limit, above all of these: compound 3.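

In this assay compound 4 gives 64200 nM, a measured number, with the (tert-butyl)carbonyl ester in place of hydrogen on this oxygen. The change reads as an at least 1.5-fold lower number from compound 3 to compound 4 (0.19 log units; that floor lies within the scatter), so the data show no step beyond the scatter. That figure is only a floor, because compound 3 sits at a limit of the assay: the limit of > 100000 nM in this assay, at which 1 of the 4 values shown sits. Still open, from the compounds shown here alone, is how far the true step reaches, and whether an ester with a longer chain or one carrying an amine at this oxygen would shift the number.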